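Ether-linked side chain in place of dimethylamino on the core

A few compounds are considered here, and "the series" means these few. Any claim that something is new, unique, unknown or untested is made for them only; others in the source may bear on it.

Compound 3 `CN(C)c1c(F)c(N)c2c(=O)cc(-c3ccc(N)c(F)c3)oc2c1F` is one of the three members measured in a functional assay on HeLa cells (Homo sapiens) for cytotoxicity, read by neutral red uptake, with a stated time of 3 days; a higher number here means a weaker inhibitor, a lower number a stronger inhibitor. In this assay compound 3 gives only a limit, > 100000 nM. Compound 1 `Nc1ccc(-c2cc(=O)c3c(N)c(F)cc(F)c3o2)cc1F` likewise reaches only a limit in this assay, > 100000 nM. For the measured compounds named here, compound 2 `Nc1ccc(-c2cc(=O)c3c(N)c(F)c(CO)c(F)c3o2)cc1F` is the single member with a number: in this assay compound 2 gives 24000 nM. Two of the three values therefore sit at the same limit, (the limit of > 100000 nM in this assay, at which 2 of the 3 values shown sit), which leaves compound 3 readable only against compound 2.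

Compound 4 `CCCCCCOCc1c(F)c(N)c2c(=O)cc(-c3ccc(N)c(F)c3)oc2c1F` is not yet measured. It differs from compound 3 in one place: (hexyloxy)methyl in place of dimethylamino on an aromatic carbon.

Going by the values given here, two measured steps bear on this. Hydroxymethyl on that carbon gave an at least 4.1-fold lower number from compound 1 to compound 2 (0.61 log units; beyond the scatter), and its replacement by dimethylamino gave an at least 4.1-fold higher number from compound 2 to compound 3 (0.61 log units; beyond the scatter). The (hexyloxy)methyl group carries the same carbon-linked, oxygen-bearing arm as hydroxymethyl rather than a nitrogen; the expectation is therefore a move back toward compound 2, a step of an at least 2.5-fold lower number from compound 3 to compound 4 (0.39 log units; beyond the scatter), though from a limit its size remains uncertain. For compound 4 the expected value in this assay is 40000 nM, in the range 10000 nM to 150000 nM.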

Compound 4, half-maximal inhibitory concentration: > 100000 nM
Compound 4: a limit, no number; the forecaster's own chance of this, stated with the estimate: 40%; middle value at least 2.5-fold (0.39 log units) away from the limit.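

Hexyl in place of hydrogen on the oxygen gives an at least 4.1-fold higher number from compound 2 to compound 4 (0.61 log units; beyond the scatter) in this assay, so the carbon-linked oxygen arm alone does not carry the lower number of compound 2, and of the groups shown on this aromatic carbon only hydroxymethyl gives a number. For compound 4 > 100000 nM is a limit, not a number. The steps from compound 1 and compound 3 to compound 4 cannot be read, because both ends of each sit at the same limit: the limit of > 100000 nM in this assay, at which 3 of the 4 values shown sit.

On these data alone, how short an ether chain must be to return a number stays open, with methoxymethyl or ethoxymethyl as the nearest cases. Also open, as far as these compounds go, is whether an aminomethyl group or a carboxylic acid on this carbon would give a number as hydroxymethyl does.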